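The compounds below may be only part of what the source reports. "The series", "measured", "known", "first", "only" and "open" are said of these compounds alone.

In an ADME assay on HaCaT cells (Homo sapiens) for inhibition, read by sulforhodamine B assay, with a stated time of 48 h (on this read-out lower numbers stand for stronger inhibition of growth and higher numbers for weaker inhibition of growth), compound 1 `CC(C)(C)NCc1c(C(=O)O)nn(-c2ccccc2)c1-c1ccc(F)cc1` gives > 680000 nM, which is a limit of the assay and not a number. In this assay compound 2 `Cc1ccc(-c2c(CNC(C)(C)C)c(C(=O)O)nn2-c2ccccc2)cc1` gives > 688000 nM, which is also a limit. Within the data shown here, compound 2 therefore has no exact position on the scale, and the only other value available is a limit too.

Compound 3 `CC(C)(C)NCc1c(C(=O)O)nn(-c2ccccc2)c1-c1ccc([N+](=O)[O-])cc1` has not yet been measured. It carries nitro in place of methyl on an aromatic carbon, para to a large group, so that 4-methylphenyl becomes 4-nitrophenyl: nitro in place of methyl on an aromatic carbon.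

Among the measured compounds shown here, the one measured step that bears on this change is a step that the two limits leave unreadable from compound 1 to compound 2, with methyl in place of fluoro on that same aromatic carbon. It offers no size to carry over, and neither replacement has yet produced a readable value. No step beyond the scatter is therefore expected in this assay, in either direction.

The estimated change is an at least 1.0-fold lower number from compound 2 to compound 3 (0.03 log units; that floor lies within the scatter). Compound 3 is expected to read about 640000 nM, with an estimated range from 320000 nM to 1000000 nM.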

Compound 3, concentration for 50% growth inhibition: > 634000 nM
Compound 3 was reported as a limit; the forecaster's own chance of this, stated with the estimate: 85%; the middle value lies beyond the limit too.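

In this assay compound 3 gives > 634000 nM, which is a limit and not a number. Among these compounds, compound 1 and compound 2 also stand at limits, so no step among compound 1, compound 2 and compound 3 can be read. The compounds shown leave open whether fluoro, methyl or nitro on this aromatic carbon changes growth inhibition at all.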